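Changing the Ether Chain on a Growth Inhibitor

This account rests on a few compounds, and the source may have more. Where it says the series, first, only, none or still open, it means among the compounds named here.

In a functional assay on NCI-H23 cells (Homo sapiens) for antiproliferative activity, read by sulforhodamine B assay (on this read-out lower numbers stand for stronger inhibition of growth and higher numbers for weaker inhibition of growth), compound 1 `COc1cccc(OCCC(C)(C)C)c1C(=O)/C=C/c1ccc(O)cc1` reads > 30000 nM, which is a limit of the assay and not a number. Compound 2 `CC(C)(C)CCOc1cccc(O)c1C(=O)/C=C/c1ccc(C(=O)O)cc1` gives 4770 nM, and compound 3 `CC(C)(C)CCOc1cccc(O)c1C(=O)/C=C/c1ccc(O)cc1` gives 3130 nM, so these two stand level within the scatter. Hydrogen in place of methyl on an oxygen on an aromatic ring gave an at least 9.5-fold lower number from compound 1 to compound 3 (0.98 log units; beyond the scatter). Hydroxy in place of carboxy on an aromatic carbon gave a 1.5-fold lower number from compound 2 to compound 3 (0.18 log units; within the scatter). Compound 4 `O=C(/C=C/c1ccc(O)cc1)c1c(O)cccc1OCC1CCCCC1` instead changes the chain: cyclohexyl in place of neopentyl on a saturated chain carbon bound to an oxygen on an aromatic ring. Neither measured step touched that chain, so no change beyond the scatter is expected, and compound 3 at 3130 nM serves as the anchor. The expected change is a 1.0-fold lower number from compound 3 to compound 4 (0.02 log units; within the scatter). For compound 4 the estimate is 3000 nM, with an expected range of 1200 nM to 8000 nM.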

Compound 4, concentration for 50% growth inhibition: > 30000 nM
Compound 4: a limit, no number; the forecaster's own chance of this, stated with the estimate: 10%; middle value at least 10-fold (1.00 log units) from the limit.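

In this assay the ether chain proves to matter: cyclohexyl in place of neopentyl gave an at least 9.5-fold higher number from compound 3 to compound 4 (0.98 log units; beyond the scatter) on the same core. Going by these compounds alone, the earlier steps changed other groups, so this is the first sign that the read-out is sensitive to this position. On these data alone, compound 4 carries a limit and not a number, so the full size of its step remains unknown: the limit of > 30000 nM in this assay, at which 2 of the 4 values shown sit.

Still open, as far as these compounds go, is whether a longer chain or a chain ending in an amine would retain the growth inhibition of compound 3. It is also unclear whether the ring itself matters, or whether any replacement for neopentyl at this position would behave the same way.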